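Purine nucleoside series: swapping the aryl on the thioether

The source may hold more compounds than are shown below. What is called first, only, known or untested is meant among the compounds shown, and "the series" means these compounds.

Compound 1, `O=[N+]([O-])c1cccc2c1CCN(c1ncnc3c1ncn3[C@@H]1O[C@H](CO)[C@@H](O)[C@H]1O)C2`, gives 3020 nM in an assay on isolated protein for binding affinity to Equilibrative nucleoside transporter 1 (Homo sapiens); a higher number here means a weaker inhibitor, a lower number a stronger inhibitor.
Compound 2, `CSc1ncnc2c1ncn2C1CCCCO1`, gives 275000 nM in this assay.
Compound 3, `Nc1nc(SCc2ccc(Br)cc2)c2ncn([C@@H]3O[C@H](CO)[C@@H](O)[C@H]3O)c2n1`, gives 813 nM in this assay.

Compound 3 holds the lowest number of the three, and its gaps to compound 1 and to compound 2 both lie beyond the scatter. Compound 4, `Cc1cccc(CSc2nc(N)nc3c2ncn3[C@@H]2O[C@H](CO)[C@@H](O)[C@H]2O)n1`, differs from compound 3 only by 6-methylpyridin-2-yl in place of 4-bromophenyl on a saturated chain carbon bound to a sulfur. Among the measured compounds shown here, no measured pair shows this change, so no step size can be read from the series. The shared core and the sugar stay the same; the expectation is for a step from compound 3 to compound 4 of a 1.2-fold higher number from compound 3 to compound 4 (0.09 log units; within the scatter) in this assay, not beyond the scatter. Compound 4 is estimated at 1000 nM, within 300 nM to 3500 nM.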

Compound 4, half-maximal inhibitory concentration: 11500000 nM
Compound 4: the middle estimate sits 12000-fold (4.06 log units) below what was measured; measured number outside the range, above it.
By their numbers in this assay, from the lowest: compound 3; then compound 1; then compound 2; then compound 4.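

In this assay, among the compounds shown here, the first readable step is a 14000-fold higher number from compound 3 to compound 4 (4.15 log units; beyond the scatter) for 6-methylpyridin-2-yl in place of 4-bromophenyl on a saturated chain carbon bound to a sulfur. This position is therefore far from indifferent to the aryl, even though both groups hold 7 heavy atoms and one six-membered aromatic ring. Nothing available accounts for the size of this step.

As far as these compounds go, the ring nitrogen, the methyl and the lost bromine all change at once, so their shares stay open. An unsubstituted benzyl or a pyridin-2-ylmethyl on the same sulfur would begin to separate them.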